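The source may report more compounds than this note shows. Statements on the series, on what has been measured and on what is new or still open speak of the compounds shown alone.

Measured compounds in a functional assay on HL-60 cells (Homo sapiens) for cytotoxicity, read by luminescence and CellTiter-Glo, with a stated time of 3 days; a higher number here means a weaker inhibitor, a lower number a stronger inhibitor:
- compound 1 `N#Cc1ccc(NC(=O)c2ccc(Br)cc2O)cc1Cl` gives 440 nM
- compound 2 `N#Cc1ccc(NC(=O)c2ccc(Br)cc2O)cc1` gives 1210 nM
- compound 3 `N#Cc1ccc(NC(=O)c2ccc(Br)cc2O)c(Cl)c1` gives 730 nM

Compound 2 has the highest of the three numbers in this assay. Its nearest neighbour is compound 3, and the step of a 1.7-fold lower number from compound 2 to compound 3 (0.22 log units; within the scatter) lies within the scatter; the step of a 2.8-fold higher number from compound 1 to compound 2 (0.44 log units; beyond the scatter) lies beyond it. Both measured steps concern a single chloro on an aromatic carbon; neither touches the bromo of compound 2.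

Compound 4 `N#Cc1ccc(NC(=O)c2ccc(-c3ccccc3)cc2O)cc1` is the unmeasured compound. It differs from compound 2 by phenyl in place of bromo on an aromatic carbon. For the measured compounds named here, no measured step alters that position, so the measured steps give no direction for this change. The two steps that exist, a 2.8-fold higher number from compound 1 to compound 2 (0.44 log units; beyond the scatter) and a 1.7-fold lower number from compound 2 to compound 3 (0.22 log units; within the scatter), show that single-group changes elsewhere moved this assay by modest amounts at most, but they do not bear on a replacement of the bromo. For compound 4 the expected step is therefore a 1.0-fold lower number from compound 2 to compound 4 (0.00 log units; within the scatter), a placeholder for no directional information rather than a prediction of no effect. Compound 4 is expected to give 1200 nM, with a wide range from 300 nM to 4800 nM reflecting the absence of supporting data.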

Compound 4, half-maximal inhibitory concentration: 700 nM
Beside the measured number, compound 4's estimate is 1.7-fold (0.23 log units) above it; measured number inside the range.
By their numbers in this assay, from the lowest: compounds 1, 4, 3 and 2 (each within the scatter of the next, the first and the last beyond it).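

For the compounds shown here, the first measured change at this position, in this assay, replaces bromo with phenyl (a 1.7-fold lower number from compound 2 to compound 4 (0.24 log units; within the scatter)). The entering group has 6 heavy atoms and a six-membered aromatic ring of carbon only, against 1 heavy atom and no ring for the group it replaces, yet the step stays within the scatter, so this pair gives no sign that the position is closed to an aromatic ring. Nothing available here explains why the two groups read alike in this cytotoxicity measurement.

From the compounds shown here alone, whether an amine, a carboxylic acid or a longer chain in place of the bromo would also stay within the scatter of compound 2 remains open, since a single replacement cannot show how far this position reaches. Also open is whether the chloro of compound 1 would give the same step when phenyl stands in place of bromo, as no compound shown carries both groups.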